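Series notes: aryl and heteroaryl variation at the thiophene position

The source may report more compounds than this note shows. Statements on the series, on what has been measured and on what is new or still open speak of the compounds shown alone.

Compound 3 `COc1ccc(-c2sc(N)c(C(=O)c3ccc(Cl)cc3)c2CC(C)(C)C)cc1` sits at 1% in an assay on CHO cells for displacement of a labelled ligand from adenosine receptor A1 (Homo sapiens), read by scintillation counting, tested at 10 uM (a higher number here means more inhibition at the concentration tested (going by the name of the read-out), a lower number less inhibition), level with compound 1 `COc1cccc(-c2sc(N)c(C(=O)c3ccc(Cl)cc3)c2CC(C)(C)C)c1` at 1% and compound 2 `CC(C)(C)Cc1c(Br)sc(N)c1C(=O)c1ccc(Cl)cc1` at 1%. The three measured steps all turn on the same aromatic carbon: no change at the digits printed from compound 1 to compound 2 (within the scatter), no change at the digits printed from compound 1 to compound 3 (within the scatter) and no change at the digits printed from compound 2 to compound 3 (within the scatter). Every exchange there, whether bromo or either methoxyphenyl, left the read-out where it stood.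

Compound 4 `Cc1noc(C)c1-c1sc(N)c(C(=O)c2ccc(Cl)cc2)c1CC(C)(C)C` alters that same carbon: 3,5-dimethyl-1,2-oxazol-4-yl in place of 4-methoxyphenyl on an aromatic carbon

The three prior steps at this position bear directly on the change and were each within the scatter, so no movement beyond the scatter is expected in this assay; the expected step is no change at the digits printed from compound 3 to compound 4 (within the scatter). Compound 4 is therefore estimated at 1%, with a range from -8% to 10%.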

Compound 4, a percentage reported as inhibition, at one concentration (the size of the read-out at that concentration, not a potency): 1%
Estimate against measurement, compound 4: no gap at the digits printed, and the stated range covers the measured number.
By their numbers in this assay, from the lowest: compounds 1, 2, 3 and 4 (each within the scatter of the next).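

In this assay, a five-membered aromatic ring with 2 hetero atoms now stands on this carbon alongside bromo and the methoxyphenyl groups, and the steps show no separation (no change at the digits printed from compound 3 to compound 4 (within the scatter); no change at the digits printed from compound 2 to compound 4 (within the scatter); no change at the digits printed from compound 1 to compound 4 (within the scatter)). The level read-out at this position therefore extends to a different ring size and to 3,5-dimethyl-1,2-oxazol-4-yl with its 2 hydrogen-bond acceptors. No evidence here accounts for this result.

As far as these compounds go, whether an amine or a carboxylic acid on this carbon would lift the read-out remains open. So does whether a longer chain in place of the neopentyl group would do so.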